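Chloro in Place of Hydrogen on the Phenyl of Compound 1

The compounds below may be only part of what the source reports. "The series", "measured", "known", "first", "only" and "open" are said of these compounds alone.

Compound 1 `Cc1nc(-c2ccccc2)sc1COc1ccc2c(c1)OCC2CC(=O)O` gives 54.8% in a functional assay on CHO cells for agonist activity at Free fatty acid receptor 1 (Homo sapiens), read by FLIPR and calcium flux, tested at 100 nM; on this read-out higher numbers stand for a stronger effect at the one concentration tested and lower numbers for a weaker effect.
Compound 2 `Cc1nc(-c2cc3ccccc3o2)sc1COc1ccc2c(c1)OCC2CC(=O)O` gives 14.8% in this assay.
Compound 3 `Cc1nc(-c2cccc(Cl)c2)sc1COc1ccc2c(c1)OCC2CC(=O)O` gives 43% in this assay.

Of the three measured compounds, compound 1 stands highest in this assay. Its nearest neighbour is compound 3, and the step of a number 11.8 percentage points lower from compound 1 to compound 3 (beyond the scatter) is beyond the scatter; the furthest is compound 2, reached by a number 40 percentage points lower from compound 1 to compound 2 (beyond the scatter), a large fall. The unmeasured compound 4 `Cc1nc(-c2ccc(Cl)cc2)sc1COc1ccc2c(c1)OCC2CC(=O)O` differs from compound 1 by chloro in place of hydrogen on an aromatic carbon, placed para to a large group on the phenyl, so that phenyl becomes 4-chlorophenyl.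

The step that bears most directly on this change is a number 11.8 percentage points lower from compound 1 to compound 3 (beyond the scatter), where chloro in place of hydrogen at another carbon of the same phenyl gave a modest loss. The step of a number 40 percentage points lower from compound 1 to compound 2 (beyond the scatter) concerns a different, ring-bearing replacement and is less comparable. On that basis compound 4 is expected to sit somewhat below compound 1, with a modest step of a number 7.8 percentage points lower from compound 1 to compound 4 (within the scatter), the same direction as the other chloro step and possibly within the scatter. Compound 4 is therefore estimated at 47%, with a range from 30% to 64%.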

Compound 4, a percentage reported as activity, at one concentration (the size of the read-out at that concentration, not a potency): 53.4%
For compound 4 the middle estimate is 6.4 percentage points below the measured one, and the stated range covers the measured number.
By their numbers in this assay, from the lowest: compound 2; then compound 3; then compounds 4 and 1 (each within the scatter of the next).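

In this assay the change from phenyl to 4-chlorophenyl, with chloro para to a large group, gives a number 1.4 percentage points lower from compound 1 to compound 4 (within the scatter) and so leaves the read-out of the core of compound 1 intact at this concentration. The place of the chloro on the phenyl therefore counts: moving from the 3-chlorophenyl to the 4-chlorophenyl gives a number 10.4 percentage points higher from compound 3 to compound 4 (beyond the scatter) and shows that the loss seen with compound 3 does not follow from a chloro on this phenyl wherever it sits. The 4-chlorophenyl also stands well clear of the 1-benzofuran-2-yl group, with a number 38.6 percentage points higher from compound 2 to compound 4 (beyond the scatter) as the step, so a chloro at this carbon keeps the level of the plain phenyl rather than moving towards that of compound 2.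

Nothing at hand explains why the two chloro placements part ways. Going by these compounds, whether a fluoro, a methyl, a methoxy or a trifluoromethyl at this same carbon would match the chloro stays open, and a reading at a single concentration cannot say whether compound 1 and compound 4 also match in potency.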